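Azetidinone series: aryl swap from compound 3 to compound 4

The source may report more compounds than this note shows. Statements on the series, on what has been measured and on what is new or still open speak of the compounds shown alone.

Compound 3 `COC(=O)/C(=C/c1ccccc1)CN1C(=O)[C@@H](OC)[C@H]1c1ccc(OC)cc1` carries a 4-methoxyphenyl group on the saturated ring carbon of the shared core. In an ADME assay on cells (Epithelial cell, Homo sapiens) for antiproliferative activity, read by MTT assay, with a stated time of 48 h (a higher number here means a weaker inhibitor, a lower number a stronger inhibitor), compound 3 gives "not toxic" (no number reported), so no number stands for it and it cannot be ranked against the numbered compounds. Those are compound 1 `COC(=O)/C(=C/c1ccccc1)CN1C(=O)[C@@H](OC)[C@H]1c1ccc(Cl)cc1`, which in this assay gives 37900 nM, and compound 2 `COC(=O)/C(=C/c1ccccc1)CN1C(=O)[C@@H](OC)[C@H]1c1cccc(F)c1`, which gives 38500 nM. The step of a 1.0-fold higher number from compound 1 to compound 2 (0.01 log units; within the scatter) shows that exchanging one halogenated aryl for another leaves the read-out flat.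

Compound 4 `COC(=O)/C(=C/c1ccccc1)CN1C(=O)[C@@H](OC)[C@H]1c1ccc(F)cc1` differs from compound 3 by fluoro in place of methoxy on an aromatic carbon. Among the measured compounds shown here, no measured step covers a methoxy leaving, so the only guide is that both numbered halogenated analogues sit close together and compound 3 itself was reported without a number. The 4-fluorophenyl of compound 4 resembles the 4-chlorophenyl of compound 1 more than it does the methoxy analogue, so a weak inhibitor near the numbered pair is expected in this assay, with a real chance that only a limit is reported. Compound 4 is expected to give about 45000 nM, within a range from 20000 nM to 120000 nM.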

Compound 4, half-maximal inhibitory concentration: 27900 nM
Estimate against measurement, compound 4: 1.6-fold (0.21 log units) above; the measured number falls inside the stated range.
By their numbers in this assay, from the lowest: compounds 4, 1 and 2 (each within the scatter of the next).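

In this assay the earlier step changed the halogen and its place together, whereas these two separate them: 4-fluorophenyl in place of 3-fluorophenyl gives a 1.4-fold lower number from compound 2 to compound 4 (0.14 log units; within the scatter) and fluoro in place of chloro gives a 1.4-fold lower number from compound 1 to compound 4 (0.13 log units; within the scatter) and so neither change alone moves the number beyond the scatter among these three compounds. The step between the methoxy and fluoro analogues cannot be read, since compound 3 has no number. No measurement available here explains the closeness of these values.

Still open, going by these compounds, is whether an amine or a carboxylic acid in place of the halogen on this aryl group would shift the number beyond the scatter. Also open is how far the number depends on the methyl ester of the shared core, which stays the same in all the compounds shown.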